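A Methylsulfanyl Group Enters Where Compound 1 Carries Hydrogen

A few compounds are considered here, and "the series" means these few. Any claim that something is new, unique, unknown or untested is made for them only; others in the source may bear on it.

Compound 1 `CCN(c1ccc(C(C)C)cc1)c1nc(C)cc(C)n1` was examined in an assay on isolated protein for binding affinity to corticotropin-releasing factor receptor 1 (Homo sapiens); on this read-out higher numbers stand for weaker inhibition and lower numbers for stronger inhibition. In this assay compound 1 gives > 1000 nM, which is a limit of the assay and not a number. Compound 1 thus stands at the limit of > 1000 nM in this assay, at which 1 of the 3 values shown sits. Two further compounds with the same core were measured as well. Compound 2 `CCCN(CCC)c1nc(C)nc(N(CC)c2ccc(N(C)C)cc2C(F)(F)F)n1` gives 6 nM in this assay, and compound 3 `CCN(c1nc(C)cc(C)n1)c1ccc(N(C)C)cc1C` gives 54 nM. Both of those values lie well inside the measurable range, while compound 1 does not.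

Compound 4 `CCN(c1nc(C)cc(C)n1)c1ccc(C(C)C)cc1SC` has not yet been measured. It differs from compound 1 by methylsulfanyl in place of hydrogen on an aromatic carbon. Going by the values given here, no step between two measured compounds covers this particular change, so its size has to be estimated. Since compound 1 reaches only a limit, any measurable number for compound 4 would already mean a gain. The expected step of an at least 8.3-fold lower number from compound 1 to compound 4 (0.92 log units; beyond the scatter) is a clear improvement, beyond the usual scatter. Compound 4 is therefore estimated at about 120 nM, with a likely range from 25 nM to 600 nM.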

Compound 4, inhibition constant: 36 nM
Compound 4: middle estimate off by 3.3-fold (0.52 log units), on the high side; low and high end bracket the measured number.
By their numbers in this assay, from the lowest: compound 2; then compounds 4 and 3 (each within the scatter of the next). At a limit, above all of these: compound 1.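

Placed on this aromatic carbon, ortho to a large group and meta to an isopropyl group, methylsulfanyl gives in this assay an at least 27-fold lower number from compound 1 to compound 4 (1.44 log units; beyond the scatter). Going by these compounds alone, this is the first step between two measured compounds, and it shows that a change of just this one group is enough to bring the core of compound 1 into the measurable range. The step gives only a lower bound on the size of the change, since compound 1 rests on a limit and not a number: the limit of > 1000 nM in this assay, at which 1 of the 4 values shown sits.

From the compounds shown here alone, it remains open whether the gain needs the sulfur or would also come with a methoxy group, a chlorine atom or a plain methyl group on the same carbon. A longer chain on the sulfur, such as ethylsulfanyl, would show whether this position accepts more than methylsulfanyl.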